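Isopropyl in place of aryl on an isoindolinone-type modulator

The compounds below may be only part of what the source reports. "The series", "measured", "known", "first", "only" and "open" are said of these compounds alone.

Measured compounds:
compound 1 `O=C(O)c1cc(-c2cccc(COc3ccc4c(=O)n(C5CCCC5)oc4c3)c2)ccc1Cl` — 64%
compound 2 `O=C(O)c1cc(-c2cccc(COc3ccc4c(c3)CN(Cc3ccc(C(F)(F)F)cc3)C4=O)c2)ccc1Cl` — 86.7%

In an assay on HEK293 cells for positive allosteric modulation of metabotropic glutamate receptor 2 (Rattus norvegicus), read by thallium flux (on this read-out higher numbers stand for larger maximal responses and lower numbers for smaller maximal responses), compound 2 gives 86.7%, the highest of the two numbers shown. Among the compounds with values here, its nearest neighbour is compound 1, which in this assay gives 64%, a gap that lies beyond the usual scatter; the two share only part of their structure, so no single step links them. Compound 3 `CC(C)CN1Cc2cc(OCc3cccc(-c4ccc(Cl)c(C(=O)O)c4)c3)ccc2C1=O` is not yet measured. It differs from compound 2 in one place: isopropyl in place of 4-(trifluoromethyl)phenyl on a saturated chain carbon bound to an amide-type nitrogen in a ring.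

Within the data shown here, no measured pair shows what this kind of exchange does in this assay. Compound 3 is expected to land somewhat lower than compound 2, a step of a number 14.7 percentage points lower from compound 2 to compound 3 (beyond the scatter), probably beyond the scatter but with wide uncertainty. For compound 3 the estimated value is 72%, with a range from 50% to 92%.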

Compound 3, largest response reached (Emax), in percent of the reference or control that the assay uses: 63.9%
Beside the measured number, compound 3's estimate is 8.1 percentage points above it; the range from low to high includes it.
By their numbers in this assay, from the lowest: compounds 3 and 1 (each within the scatter of the next); then compound 2.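

In this assay, within the data shown here, putting isopropyl in place of 4-(trifluoromethyl)phenyl on a saturated chain carbon bound to an amide-type nitrogen in a ring gives a number 22.8 percentage points lower from compound 2 to compound 3 (beyond the scatter), the first single-place reading at this position. It shows that the maximal response depends on the group at this position, yet the exchange, which removes a six-membered aromatic ring of carbon only and takes the group from 10 heavy atoms to 3, still leaves compound 3 with 63.9%. Nothing available explains this step.

This single exchange does not separate the loss of the aromatic ring from the loss of the trifluoromethyl group or from the smaller group size. As far as these compounds go, whether an unsubstituted phenyl, a cyclohexyl or a longer chain at this place would keep the higher response remains open.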